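A few compounds are considered here, and "the series" means these few. Any claim that something is new, unique, unknown or untested is made for them only; others in the source may bear on it.

Values in a functional assay on WiDr cells (Homo sapiens) for antiproliferative activity, read by sulforhodamine B assay, with a stated time of 48 h (a lower number here means a stronger inhibitor of growth, a higher number a weaker inhibitor of growth), all three of them limits:
compound 1 `CC(C)(C)[Si](C)(C)O[C@H]1CCCO[C@@H]1CO` gives > 100000 nM
compound 2 `CC(C)(C)[Si](C)(C)O[C@@H]1CCCO[C@@H]1CO` gives > 100000 nM
compound 3 `O=C1COC[C@H]2OCCC[C@H]2O1` gives > 100000 nM

Compound 2 stands only as a limit, > 100000 nM. Among the measured compounds shown here, the whole series so far rests on (the limit of > 100000 nM in this assay, at which 3 of the 3 values shown sit), so no number is yet available as a starting point. Compound 4 `COC(=O)CCOC[C@H]1OCCC[C@H]1O[Si](C)(C)C(C)(C)C`, not yet measured, carries 2-(methoxycarbonyl)ethyl in place of hydrogen on an oxygen on a saturated carbon; the hydroxy becomes 2-(methoxycarbonyl)ethoxy. For the measured compounds named here, the only measured step is a step that the two limits leave unreadable from compound 1 to compound 2. That step concerns (the fact that compounds 1 and 2 differ only in the configuration as drawn), has no readable size and says nothing about a new group on the oxygen. The expectation therefore rests on the three limits alone, and none of those compounds shows growth inhibition that could be read in this assay. No step beyond the scatter is expected, and a reading at the limit again is the likeliest outcome. The estimated step is a number no higher from compound 2 to compound 4 (the limit leaves the size open). Compound 4 is estimated at 100000 nM, with an expected range from 30000 nM to 200000 nM.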

Compound 4, concentration for 50% growth inhibition: > 100000 nM
Compound 4 ended at the assay's limit; the forecaster's own chance of this, stated with the estimate: 80%; the middle value lies on the limit itself.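

Compound 2 and compound 4 both sit at the limit of this assay, so no step can be read between them. The compounds shown leave open whether any group on this oxygen would give growth inhibition that can be read in this assay.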